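Oxazole ketones: aryl variation at the five-membered ring

The compounds below may be only part of what the source reports. "The series", "measured", "known", "first", "only" and "open" are said of these compounds alone.

Measured compounds:
compound 1, `Cc1coc(C(=O)CCCCCCc2ccccc2)n1` — > 10000 nM
compound 2, `O=C(CCCCCCc1ccccc1)c1nc(-c2ccccc2)co1` — 8710 nM

For the measured compounds named here, in an assay on HEK-293T cells for inhibition of diacylglycerol lipase-alpha (Homo sapiens), read by colorimetric assay (a higher number here means a weaker inhibitor, a lower number a stronger inhibitor), compound 2 gives 8710 nM, the only number so far. The value of compound 1 is a limit of the assay, (the limit of > 10000 nM in this assay, at which 1 of the 2 values shown sits), and not a number. Going by the values given here, compound 2 therefore stands at the one numerical point of the series; no other measured compound can be placed on the scale against it.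

The next compound, compound 3, `O=C(CCCCCCc1ccccc1)c1nc(-c2ccncc2)co1`, differs from compound 2 in a single position: pyridin-4-yl in place of phenyl on an aromatic carbon.

Among the compounds with values here, the only measured step, an at least 1.1-fold lower number from compound 1 to compound 2 (0.05 log units; that floor lies within the scatter), concerns a different change at the same aromatic carbon, and it lies within the scatter. Within the data shown here, it says nothing about exchanging one six-membered aromatic ring for another, and no measured pair addresses a carbon-to-nitrogen exchange in that ring. The expectation for compound 3 in this assay is therefore a step of no clear size or direction beyond the scatter, a 1.0-fold higher number from compound 2 to compound 3 (0.01 log units; within the scatter), and compound 3 is estimated at 9000 nM, with a range from 3000 nM to 30000 nM.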

Compound 3, half-maximal inhibitory concentration: > 10000 nM
Compound 3: only a limit was reported; the forecaster's own chance of this, stated with the estimate: 40%; middle value at least 1.1-fold (0.04 log units) away from the limit.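

Compound 3 gives > 10000 nM in this assay and this is a limit of the assay, not a number. Placing pyridin-4-yl on this aromatic carbon, with its ring nitrogen and hydrogen-bond acceptor, therefore does not bring a second number onto the scale, and the exchange for phenyl reads as an at least 1.1-fold higher number from compound 2 to compound 3 (0.05 log units; that floor lies within the scatter), so neither a loss nor a gain can be claimed from this pair. The step between compound 1 and compound 3 cannot be read, because both values are limits, and compound 2 remains the only numerical point in the series: the limit of > 10000 nM in this assay, at which 2 of the 3 values shown sit.

From the compounds shown here alone, how far compound 3 actually lies from compound 2 stays open, and the ring nitrogen's contribution at this position cannot be separated from the limit. Also open, going by these compounds, is how this aromatic carbon responds to pyridin-3-yl, or to a phenyl ring carrying an amine or a carboxylic acid, and whether any such group gives a value well clear of the limit.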